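From bromo to fluoro: what to expect for compound 4

The source may hold more compounds than are shown below. What is called first, only, known or untested is meant among the compounds shown, and "the series" means these compounds.

Compound 1 `O=C1NC(=S)/C(=C/c2ccc(Cl)cc2)S1` gives 3.91%
Compound 2 `O=C1NC(=S)/C(=C/c2ccc(Br)cc2)S1` gives -0.36%
Compound 3 `O=C1NC(=S)/C(=C/c2cccc(F)c2)S1` gives 7.03%

These numbers come from a functional assay on HEp-2 cells (Homo sapiens) for cytotoxicity, read by MTT assay, with a stated time of 72 h, tested at 2.5 ug/mL (a higher number here means more inhibition of growth at the concentration tested, a lower number less inhibition of growth), and sit close together. Compound 2 stands within the usual scatter of both compound 1 and compound 3, so no order can be drawn between them.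

Compound 4 `O=C1NC(=S)/C(=C/c2ccc(F)cc2)S1` is still unmeasured. It differs from compound 2 by fluoro in place of bromo on an aromatic carbon. The closest measured evidence is a number 4.3 percentage points lower from compound 1 to compound 2 (within the scatter) (bromo in place of chloro on an aromatic carbon), which stays within the scatter. Compound 3 also carries a fluoro group and gives 7.03% in this assay as well. No step beyond the scatter is therefore expected, and the estimated step is a number 4.4 percentage points higher from compound 2 to compound 4 (within the scatter) (no firm direction). Compound 4 is estimated at 4% (expected range -5% to 14%).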

Compound 4, percent growth inhibition at one concentration: -4.51%
For compound 4 the middle estimate is 8.5 percentage points above the measured one; the range from low to high includes it.
By their numbers in this assay, from the lowest: compounds 4, 2, 1 and 3 (each within the scatter of the next, the first and the last beyond it).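

Fluoro now joins chloro and bromo on this aromatic carbon, and the swap stays small in this assay (  a number 4.2 percentage points lower from compound 2 to compound 4 (within the scatter)) and (a number 8.4 percentage points lower from compound 1 to compound 4 (within the scatter)), so these three halogens cannot be told apart here. Compound 3, with its fluoro group on a different ring carbon, gives 7.03% while compound 4 gives -4.51%, a gap beyond the scatter, so where fluoro sits may matter more than which halogen is used. Nothing measured here explains this.

From the compounds shown here alone, whether a non-halogen group on this carbon, such as an amine or a carboxylic acid, would give a clearly different number stays open.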